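This account rests on a few compounds, and the source may have more. Where it says the series, first, only, none or still open, it means among the compounds named here.

Of the compounds shown here, three built on one shared core have been tested in a functional assay on SK-BR-3 cells (Homo sapiens) for antiproliferative activity, read by MTT assay, with a stated time of 72 h; on this read-out lower numbers stand for stronger inhibition and higher numbers for weaker inhibition. Compound 3 `C/C=C1/[C@H](O[C@@H]2O[C@H](CO)[C@@H](O)[C@H](O)[C@H]2O)OC=C(C(=O)OC)[C@H]1CC(=O)OCCc1ccc(O)c(O)c1` is the only one of the three that returned a number: in this assay compound 3 gives 160000 nM. Compound 1 `C/C=C1/[C@H](O[C@@H]2O[C@H](CO)[C@@H](O)[C@H](O)[C@H]2O)OC=C(C(=O)OC)[C@H]1CC(=O)OCCc1ccc2c(c1)OCCO2` reached only a limit of the assay, and in this assay compound 1 gives > 20000 nM. Compound 2 `C#CCOC(=O)C[C@@H]1C(C(=O)OC)=CO[C@@H](O[C@@H]2O[C@H](CO)[C@@H](O)[C@H](O)[C@H]2O)/C1=C/C` likewise stopped at a limit, and in this assay compound 2 gives > 15000 nM. The two limits, the limit of > 15000 nM in this assay, at which 1 of the 3 values shown sits, and (the limit of > 20000 nM in this assay, at which 1 of the 3 values shown sits), leave every step among these three unreadable in size: a step that the two limits leave unreadable from compound 1 to compound 2, a step that the limit leaves unreadable from compound 1 to compound 3 and a step that the limit leaves unreadable from compound 2 to compound 3 cannot be placed on either side of the scatter.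

Compound 4 `C/C=C1/[C@H](O[C@@H]2O[C@H](CO)[C@@H](O)[C@H](O)[C@H]2O)OC=C(C(=O)OC)[C@H]1CC(=O)OCCc1ccc(O)cc1` has not yet been measured. It differs from compound 3 by hydrogen in place of hydroxy on an aromatic carbon. Within the data shown here, no measured step speaks to this change, since none of the three steps could be read. Among the measured compounds shown here, the expectation for compound 4 therefore rests on the single number for compound 3 alone, and the step of no change at the digits printed from compound 3 to compound 4 (within the scatter) is expected to stay within the usual scatter, with wide uncertainty around it. Compound 4 is estimated at 160000 nM in this assay, within a range from 40000 nM to 640000 nM.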

Compound 4, half-maximal inhibitory concentration: > 20000 nM
Compound 4: only a limit was reported; the forecaster's own chance of this, stated with the estimate: 35%; the middle value does not contradict the limit.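

Compound 4 reached only a limit of the assay, so none of its steps from compound 1, compound 2 or compound 3 can be read in size. The compounds shown leave open whether hydrogen in place of hydroxy changes the result of compound 3 in this assay, and how the varied groups rank against one another.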